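Adding a Second Hydroxymethyl Group on Two Related Cores

The compounds below may be only part of what the source reports. "The series", "measured", "known", "first", "only" and "open" are said of these compounds alone.

Compound 1 `Cc1c(CO)cc2n1[C@@H](c1ccccc1)SC2` and compound 2 `Cc1c(CO)c(CO)c2n1[C@@H](c1ccccc1)SC2` share one core and differ by hydroxymethyl in place of hydrogen on an aromatic carbon. In a functional assay on MCF7 cells (Homo sapiens) for cytotoxicity, read by MTT assay, with a stated time of 48 h (a lower number here means a stronger inhibitor, a higher number a weaker inhibitor), compound 1 gives 4300 nM, while compound 2 gives 1900 nM. The step between them is a 2.3-fold lower number from compound 1 to compound 2 (0.35 log units; beyond the scatter), a modest gain that is nonetheless beyond the usual scatter.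

Compound 3 `Cc1cc(CO)c2n1CSC2` is built on a different core; the difference between the two cores is not broken down here. In this assay compound 3 gives 54700 nM, the highest number among the three measured compounds. Its unmeasured partner is compound 4 `Cc1c(CO)c(CO)c2n1CSC2`, which differs from compound 3 by hydroxymethyl in place of hydrogen on an aromatic carbon. The surroundings of the change are not identical to the earlier case: in compound 1 the entering group sits next to the ring atom that bears a fused ring and two ring bonds from the ring atom that bears a methyl group, whereas in compound 3 it sits next to the ring atom that bears a methyl group and two ring bonds from two ring atoms that each bear a fused ring. It is therefore the same kind of change, not the same change.

A step of similar size is expected here because the other core gave a 2.3-fold lower number from compound 1 to compound 2 (0.35 log units; beyond the scatter). Resting on that single earlier case, the expected step is a 2.2-fold lower number from compound 3 to compound 4 (0.34 log units; beyond the scatter). Compound 4 is expected to give about 25000 nM in this assay, with a plausible range from 10000 nM to 60000 nM.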

Compound 4, half-maximal inhibitory concentration: 38100 nM
Compound 4: the middle estimate sits 1.5-fold (0.18 log units) below what was measured; the range from low to high includes it.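

In this assay, the hydroxymethyl change on the second core gives a 1.4-fold lower number from compound 3 to compound 4 (0.16 log units; within the scatter), a step that cannot be told apart from the variation between repeated measurements. Set beside the step on the core of compound 1, it does not differ by more than the scatter allows, so the two results are compatible with the change carrying over between these cores: the same change on two cores in this assay, a 2.3-fold lower number (0.35 log units; beyond the scatter) from compound 1 to compound 2 and a 1.4-fold lower number (0.16 log units; within the scatter) from compound 3 to compound 4, 1.6-fold (0.20 log units) apart, within the scatter of two such steps. This does not establish one fixed size for the step on other cores, as there are only two cases, the surroundings of the entering group differ between them, and the second step alone cannot be separated from no change at all, whereas hydrogen in place of phenyl on a saturated ring carbon gives a much larger step, a 20-fold higher number from compound 2 to compound 4 (1.30 log units; beyond the scatter).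

The compounds shown leave open whether an amine, a carboxylic acid or a longer chain on this aromatic carbon would give a step of a different size from hydroxymethyl. They also leave open whether a cyclohexyl ring on the saturated ring carbon would keep the lower number seen with phenyl.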